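Changing the carbonyl group of compound 3

A few compounds are considered here, and "the series" means these few. Any claim that something is new, unique, unknown or untested is made for them only; others in the source may bear on it.

Compound 3 `CCn1c(C(=O)N(C)CCC#N)ccc1C(CC)(CC)c1ccc(OCC(O)C(C)(C)C)c(C)c1` gives > 50000 nM in a functional assay on Caco-2 cells (Homo sapiens), read by MTT assay, with a stated time of 48 h (on this read-out lower numbers stand for stronger inhibition and higher numbers for weaker inhibition), which is a limit of the assay and not a number. Compound 1 `CCn1c(C(=O)NCC(OC)OC)ccc1C(CC)(CC)c1ccc(OCC(O)C(C)(C)C)c(C)c1` gives > 50000 nM, which is also a limit. Of these two neighbours, only compound 2 `CCn1c(C(=O)NCCN)ccc1C(CC)(CC)c1ccc(OCC(O)C(C)(C)C)c(C)c1` has a measured number, 1000 nM.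

Compound 4 `C#CC(C)OC(=O)c1ccc(C(CC)(CC)c2ccc(OCC(O)C(C)(C)C)c(C)c2)n1CC` differs from compound 3 on a carbonyl carbon, where (1-methylprop-2-yn-1-yl)oxy stands in place of (2-cyanoethyl)(methyl)amino: (1-methylprop-2-yn-1-yl)oxy in place of (2-cyanoethyl)(methyl)amino on a carbonyl carbon.

Among the measured compounds shown here, no measured step covers this exchange directly. Two large steps involve the (2-aminoethyl)amino group of compound 2: an at least 50-fold lower number from compound 1 to compound 2 (1.69 log units; beyond the scatter) and an at least 50-fold higher number from compound 2 to compound 3 (1.69 log units; beyond the scatter). The third, a step that the two limits leave unreadable from compound 1 to compound 3, tells us nothing about size. Compound 4 lacks that (2-aminoethyl)amino group, as do the two compounds at the limit, so no large gain is expected in this assay.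

The expected change is small, and the estimate is an at least 1.2-fold lower number from compound 3 to compound 4 (0.09 log units; that floor lies within the scatter). Compound 4 is expected near 40000 nM, with an estimated range from 10000 nM to 100000 nM, and a reading that is again only a limit is likely.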

Compound 4, half-maximal inhibitory concentration: > 50000 nM
Compound 4: only a limit was reported (the forecaster's own chance of this, stated with the estimate: 70%); middle value at least 1.2-fold (0.09 log units) from the limit.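

In this assay compound 4 gives > 50000 nM, which is a limit of the assay and not a number, so its steps from compound 1 and compound 3 cannot be read. Among the compounds shown here, the one readable step is an at least 50-fold higher number from compound 2 to compound 4 (1.69 log units; beyond the scatter); here a group joined to the carbonyl carbon through oxygen instead of nitrogen also stays outside the measured range, which only compound 2 reaches. Three different groups on this carbonyl carbon now end at the same ceiling, so any real differences among them stay hidden and the measured number at this position still rests on compound 2 alone: the limit of > 50000 nM in this assay, at which 3 of the 4 values shown sit.

The compounds shown leave open whether a longer chain ending in an amine, or a carboxylic acid, on this carbonyl carbon would also give a measured number. They also cannot rank compound 1, compound 3 and compound 4 against one another.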